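The compounds below may be only part of what the source reports. "The series", "measured", "known", "first", "only" and "open" are said of these compounds alone.

Compound 1 `CC1CCN(C2CCN(S(=O)(=O)c3cn(C)cn3)CC2)CC1` is the starting point. In a functional assay on DLD-1 cells (Homo sapiens) for antiproliferative activity, read by CellTiter-Glo, with a stated time of 72 h (a higher number here means a weaker inhibitor, a lower number a stronger inhibitor), compound 1 gives > 5000 nM, which is a limit of the assay and not a measured number, so compound 1 stands at the limit of > 5000 nM in this assay, at which 1 of the 3 values shown sits. Two further compounds carry a six-membered carbon ring on the sulfonyl sulfur and give real numbers. Compound 2 `CC1CCN(C2CCN(S(=O)(=O)c3ccccc3-c3ccc(C(F)(F)F)cc3)CC2)CC1` gives 122 nM in this assay. Compound 3 `Cc1cc(C)c(S(=O)(=O)N2CCC(N3CCCCCC3)CC2)c(C)c1` gives 5.3 nM in this assay. Compound 4 `CC1CCN(C2CCN(S(=O)(=O)c3ccc(Br)c(Cl)c3)CC2)CC1` is not yet measured and differs from compound 1 in one place: 4-bromo-3-chlorophenyl in place of 1-methyl-1H-imidazol-4-yl on a sulfonyl sulfur. Compound 2 and compound 3 show that such six-membered carbon rings on the sulfonyl sulfur go with measured, potent values. The step of an at least 160-fold lower number from compound 1 to compound 4 (2.22 log units; beyond the scatter) is therefore expected to be large, well beyond the scatter, toward stronger inhibition. Compound 4 is estimated at 30 nM, likely between 8 nM and 150 nM.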

Compound 4, half-maximal inhibitory concentration: 12 nM
For compound 4 the middle estimate is 2.5-fold (0.40 log units) above the measured one, within the range that was stated.
By their numbers in this assay, from the lowest: compound 3; then compound 4; then compound 2. At a limit, above all of these: compound 1.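

With the core of compound 1 unchanged, 4-bromo-3-chlorophenyl in place of 1-methyl-1H-imidazol-4-yl on a sulfonyl sulfur gives an at least 410-fold lower number from compound 1 to compound 4 (2.61 log units; beyond the scatter) in this assay. This shows that the group on the sulfonyl sulfur, on its own, can separate a compound with no measured number from a potent one. The true size of the step stays unknown, since compound 1 stands only at a limit of the assay: the limit of > 5000 nM in this assay, at which 1 of the 4 values shown sits.

Still open, from the compounds shown here alone, is whether the bromine, the chlorine or both are needed. Also open, going by these compounds, is how an amine or a carboxylic acid on that phenyl ring would behave.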